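One more methyl on the amine side chain

This account rests on a few compounds, and the source may have more. Where it says the series, first, only, none or still open, it means among the compounds named here.

In a functional assay for inhibition, with Homo sapiens as the target (a higher number here means that more compound is needed for the effect, a lower number that less compound is needed), compound 1 (`CCCCC(=O)Nc1ccc(C2=NNC(=O)CC2)cc1`) gives 2.64 ug/mL. Compound 2 (`CC(C)NCC(=O)Nc1ccc(C2=NNC(=O)CC2)cc1`) gives about 46.4 ug/mL, the higher of the two numbers. Compound 3 (`CCC(C)NCC(=O)Nc1ccc(C2=NNC(=O)CC2)cc1`) differs from it at one place: methyl in place of hydrogen on a saturated chain carbon, two bonds along the chain from an amine nitrogen, turning isopropylamino into (sec-butyl)amino. Among the compounds with values here, the only measured step that bears on this is an 18-fold higher number from compound 1 to compound 2 (1.24 log units; beyond the scatter), a large one, but it exchanged a whole group rather than adding a methyl. No step beyond the scatter is therefore expected in this assay, only an estimated 1.2-fold lower number from compound 2 to compound 3 (0.06 log units; within the scatter). For compound 3 the estimated value is 40 ug/mL, with an expected range of 14 ug/mL to 110 ug/mL.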

Compound 3, half-maximal effective concentration: about 21.5 ug/mL
Beside the measured number, compound 3's estimate is 1.9-fold (0.27 log units) above it, within the range that was stated.
By their numbers in this assay, from the lowest: compound 1; then compound 3; then compound 2.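

In this assay, adding a single methyl gives a 2.2-fold lower number from compound 2 to compound 3 (0.33 log units; beyond the scatter), a modest move, so this side-chain position responds to a change of one carbon, which the earlier exchange of a whole group could not show. The amine side chain still falls short of the propyl group, since (sec-butyl)amino in place of propyl gives an 8.1-fold higher number from compound 1 to compound 3 (0.91 log units; beyond the scatter), so the added methyl recovers only part of the earlier loss. Nothing available explains this shift. On these data alone, whether a longer chain on the amine, such as pentyl, or a ring, such as cyclohexyl, would lower the number further remains open.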